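The source may report more compounds than this note shows. Statements on the series, on what has been measured and on what is new or still open speak of the compounds shown alone.

Compound 1, `C(=N/N(Cc1ccccc1)Cc1ccccc1)\c1ccccc1`, is one of three hydrazones built on the same core. In an assay on liver (Sus scrofa) for inhibition of glucose-6-phosphatase catalytic subunit 1 (Homo sapiens), using microsomes (on this read-out higher numbers stand for weaker inhibition and lower numbers for stronger inhibition), compound 1 gives 1500 nM. Compound 2, `Clc1ccc(/C=N/N(Cc2ccccc2)Cc2ccccc2)cc1`, carries a chloro on the aromatic carbon and gives 240 nM; the step records a 6.3-fold lower number from compound 1 to compound 2 (0.80 log units; beyond the scatter). Compound 3, `Oc1ccc(/C=N/N(Cc2ccccc2)Cc2ccccc2)cc1`, carries a hydroxy there and gives 2400 nM; here the step is a 1.6-fold higher number from compound 1 to compound 3 (0.20 log units; within the scatter), while between the two substituted compounds the change is a 10-fold higher number from compound 2 to compound 3 (1.00 log units; beyond the scatter). Compound 1 thus stands second highest of the three numbers, close to compound 3 and clearly apart from compound 2.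

Compound 4, `C(=N/N(Cc1ccccc1)Cc1ccccc1)\c1ccco1`, differs from compound 1 by furan-2-yl in place of phenyl on a carbon with a double bond to nitrogen. For the measured compounds named here, none of the measured steps touches this change: each of them alters only a substituent on the phenyl, not the ring itself. They do show that the ring on the hydrazone carbon matters to this assay, with the chloro step reaching beyond the scatter and the hydroxy step staying within it. Going by the values given here, with no direct precedent, the exchange of the whole ring for a smaller one with one hetero atom is expected to give at most a modest step, a 1.2-fold higher number from compound 1 to compound 4 (0.08 log units; within the scatter), with the direction uncertain. Compound 4 is therefore estimated at 1800 nM, within a range from 600 nM to 5500 nM.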

Compound 4, half-maximal inhibitory concentration: 1100 nM
Compound 4: middle estimate off by 1.6-fold (0.21 log units), on the high side, within the range that was stated.
By their numbers in this assay, from the lowest: compound 2; then compounds 4, 1 and 3 (each within the scatter of the next, the first and the last beyond it).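

Furan-2-yl in place of phenyl on a carbon with a double bond to nitrogen shows that the ring itself can be exchanged in this assay, not only substituted: the change gives a 1.4-fold lower number from compound 1 to compound 4 (0.13 log units; within the scatter), so a five-membered aromatic ring with 1 hetero atom and 1 hydrogen-bond acceptor stands level with the unsubstituted phenyl. For the compounds shown here, measured against the substituted rings, compound 4 falls on different sides, with a 2.2-fold lower number from compound 3 to compound 4 (0.34 log units; beyond the scatter) for furan-2-yl in place of 4-hydroxyphenyl and a 4.6-fold higher number from compound 2 to compound 4 (0.66 log units; beyond the scatter) for furan-2-yl in place of 4-chlorophenyl, which leaves 4-chlorophenyl as the only one of the four groups whose number lies apart from all the others, and on the low side. Nothing measured here accounts for these differences.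

Still open, going by these compounds, is whether the chloro step seen on phenyl would carry over to the furan-2-yl ring, and whether a thiophene or pyridine ring would stay level with phenyl as furan-2-yl does. Equally open is how a carboxylic acid or an amine would read in place of the chloro, since the phenyl substituents shown are only chloro and hydroxy.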